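The source may hold more compounds than are shown below. What is called first, only, known or untested is meant among the compounds shown, and "the series" means these compounds.

The series shares one core carrying an amide-type nitrogen with a substituted phenyl. Compound 1 `O=C(CSc1nc(Nc2ccccc2)c2ccccc2n1)Nc1ccccc1F`, compound 2 `O=C(CSc1nc(Nc2ccccc2)c2ccccc2n1)Nc1cccc(Br)c1` and compound 3 `O=C(CSc1nc(Nc2ccccc2)c2ccccc2n1)Nc1cccc([N+](=O)[O-])c1` have been run in a functional assay on MDA-MB-231 cells (Homo sapiens) for inhibition, read by MTT assay, with a stated time of 72 h; on this read-out lower numbers stand for stronger inhibition and higher numbers for weaker inhibition. Compound 1 gives > 50000 nM, which is a limit of the assay (the limit of > 50000 nM in this assay, at which 1 of the 3 values shown sits). In this assay compound 2 gives 17500 nM. In this assay compound 3 gives 33000 nM, the highest of the two numbers recorded; its nearest neighbour is given by a 1.9-fold higher number from compound 2 to compound 3 (0.28 log units; within the scatter). Against the limit, the remaining steps read an at least 2.8-fold lower number from compound 1 to compound 2 (0.45 log units; beyond the scatter) and an at least 1.5-fold lower number from compound 1 to compound 3 (0.18 log units; that floor lies within the scatter), both only showing that leaving 2-fluorophenyl lowers the number.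

Compound 4 `CCc1cccc(NC(=O)CSc2nc(Nc3ccccc3)c3ccccc3n2)c1` is not yet measured. It differs from compound 3 by ethyl in place of nitro on an aromatic carbon. Within the data shown here, the one measured step that bears on a swap of the group at this place is a 1.9-fold higher number from compound 2 to compound 3 (0.28 log units; within the scatter), so exchanging bromo for nitro there has so far stayed within the scatter; the steps from compound 1 add nothing on ethyl. For this assay the step expected is a 1.7-fold lower number from compound 3 to compound 4 (0.22 log units; within the scatter), estimated to stay near or just inside the scatter, leaning toward a lower number. Compound 4 is estimated at 20000 nM, with a range from 8000 nM to 50000 nM.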

Compound 4, half-maximal inhibitory concentration: 12400 nM
For compound 4 the middle estimate is 1.6-fold (0.21 log units) above the measured one, within the range that was stated.
By their numbers in this assay, from the lowest: compounds 4, 2 and 3 (each within the scatter of the next, the first and the last beyond it). At a limit, above all of these: compound 1.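

In this assay, a swap confined to this aromatic carbon now gives a step beyond the scatter, a 2.7-fold lower number from compound 3 to compound 4 (0.43 log units; beyond the scatter), whereas the exchange of bromo for nitro at the same place had stayed within it. Ethyl and bromo do not separate, a 1.4-fold lower number from compound 2 to compound 4 (0.15 log units; within the scatter), so the three groups at this place do not fall into clear classes: compound 2 lies within the scatter of both compound 3 and compound 4, and only the ethyl and nitro pair stands apart. Going from 2-fluorophenyl to 3-ethylphenyl gives an at least 4.0-fold lower number from compound 1 to compound 4 (0.60 log units; beyond the scatter), the largest floor seen so far, but that step starts from a limit and so gives no true size: the limit of > 50000 nM in this assay, at which 1 of the 4 values shown sits.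

Going by these compounds, it remains open whether a longer chain such as propyl or butyl, an amine or a carboxylic acid at this place would move the number further from that of ethyl. Also open, on these data alone, is how fluoro would read at the place held by bromo, nitro and ethyl, which would separate the effect of the group from that of its place in compound 1.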